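Ether side chain variation on the shared core

The source may hold more compounds than are shown below. What is called first, only, known or untested is meant among the compounds shown, and "the series" means these compounds.

Measured compounds, read in an assay for inhibition of serine/threonine-protein kinase Sgk1 (Homo sapiens), with stated times of 30 min and 60 min, in the presence of a further agent that is not named here; on this read-out lower numbers stand for stronger inhibition and higher numbers for weaker inhibition:
compound 1 `Cc1n[nH]c2nc(-c3ccc(NS(=O)(=O)c4cc(Cl)ccc4F)cc3)nc(OCC(CO)CO)c12` gives 1 nM
compound 2 `Cc1n[nH]c2nc(-c3ccc(NS(=O)(=O)c4cc(Cl)ccc4F)cc3)nc(OC3CCC(=O)CC3)c12` gives 5 nM
compound 3 `Cc1n[nH]c2nc(-c3ccc(NS(=O)(=O)c4cc(Cl)ccc4F)cc3)nc(OCC3CN(C(C)C)C3)c12` gives 1 nM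

Compound 3 stands level with compound 1 at the digits printed, the two together holding the lowest numbers of the three; the nearest neighbour is compound 1, with no change at the digits printed from compound 1 to compound 3 (within the scatter), and the furthest is compound 2, from which a 5.0-fold lower number from compound 2 to compound 3 (0.70 log units; beyond the scatter). Among the compounds with values here, the only change that moved this assay beyond the scatter was the ketone-bearing ring of compound 2, seen in a 5.0-fold higher number from compound 1 to compound 2 (0.70 log units; beyond the scatter).

Compound 4 `Cc1n[nH]c2nc(-c3ccc(NS(=O)(=O)c4cc(Cl)ccc4F)cc3)nc(OCC3CNCCO3)c12` keeps everything of compound 3 except the group on the ether chain: morpholin-2-yl in place of 1-isopropylazetidin-3-yl on a saturated chain carbon bound to an oxygen on an aromatic ring. Within the data shown here, two measured steps bear on this position. The exchange of the dihydroxy chain for the isopropylazetidine left the number unchanged, and the ketone-bearing ring cost only a modest amount. Varied groups at this place have therefore given the same low reading twice, with one modest exception. A saturated ring with one ring nitrogen has already been accepted here in compound 3; the ring entering in compound 4 is not among those measured, so some uncertainty remains. The expectation for compound 4 is a change of a 2.0-fold higher number from compound 3 to compound 4 (0.30 log units; within the scatter), that is none beyond the scatter, giving an estimated 2 nM with a range of 0.7 nM to 6 nM.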

Compound 4, half-maximal inhibitory concentration: 2 nM
Compound 4: middle estimate and measured number agree at the digits printed; the measured number falls inside the stated range.
By their numbers in this assay, from the lowest: compounds 1, 3 and 4 (each within the scatter of the next); then compound 2.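

With morpholin-2-yl in place of 1-isopropylazetidin-3-yl on a saturated chain carbon bound to an oxygen on an aromatic ring, the reading in this assay stays within the scatter (a 2.0-fold higher number from compound 3 to compound 4 (0.30 log units; within the scatter)), so this place accepts a six-membered non-aromatic ring with 2 hetero atoms as well as a four-membered ring. The open-chain diol of compound 1 and the morpholin-2-yl group also read within the scatter of each other (a 2.0-fold higher number from compound 1 to compound 4 (0.30 log units; within the scatter)), which extends the set of unlike groups that give readings indistinguishable in this assay to three. Within the data shown here, the ketone-bearing ring remains the only group here set apart beyond the scatter, now also against the morpholine (a 2.5-fold lower number from compound 2 to compound 4 (0.40 log units; beyond the scatter)), though that step is modest.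

The compounds shown leave open whether a carboxylic acid, a primary amine or a longer chain between the ether oxygen and the ring would hold the reading at this place, and whether an isopropyl group on the morpholine nitrogen would change it. No measurement at hand offers a reason for the pattern in these readings.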